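The source may report more compounds than this note shows. Statements on the series, on what has been measured and on what is new or still open speak of the compounds shown alone.

Measured compounds:
- compound 1 `O=C(NCc1ccc(S(=O)(=O)c2cc(F)cc(F)c2)cc1)N1Cc2ccncc2C1`: 8 mL/min/kg
- compound 2 `CC(C)n1cc(S(=O)(=O)c2ccc(CNC(=O)N3Cc4ccncc4C3)cc2)cn1`: 4 mL/min/kg
- compound 3 `CCC(=O)N1CCC(S(=O)(=O)c2ccc(CNC(=O)N3Cc4ccncc4C3)cc2)CC1`: 11 mL/min/kg

The three compounds share a core and differ only in the group on the sulfonyl sulfur. In an ADME assay on microsomes from liver (Homo sapiens) for pharmacokinetics, read by LC-MS, with a stated time of 60 min, tested at 1 uM (a lower number here means slower removal, a higher number faster removal of the compound), compound 1 gives 8 mL/min/kg, the second highest of the three numbers. Its nearest neighbour is compound 3, a 1.4-fold higher number from compound 1 to compound 3 (0.14 log units; within the scatter), and its furthest is compound 2, a 2.0-fold lower number from compound 1 to compound 2 (0.30 log units; within the scatter). Within the data shown here, the one step beyond the scatter is a 2.8-fold higher number from compound 2 to compound 3 (0.44 log units; beyond the scatter), which is modest.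

Compound 4 `O=C(NCc1ccc(S(=O)(=O)N2CCOCC2)cc1)N1Cc2ccncc2C1` is not yet measured in this assay. It differs from compound 1 in one place: morpholin-4-yl in place of 3,5-difluorophenyl on a sulfonyl sulfur. The two measured steps from compound 1, to compound 2 and to compound 3, each replace the 3,5-difluorophenyl on the sulfonyl sulfur and both stay within the scatter. A new group at the same place is therefore expected to give a number close to that of compound 1, with no step beyond the scatter in either direction: the expected step is a 1.1-fold lower number from compound 1 to compound 4 (0.06 log units; within the scatter). On that basis compound 4 is estimated at 7 mL/min/kg in this assay, within a range from 3 mL/min/kg to 15 mL/min/kg.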

Compound 4, clearance: 9 mL/min/kg
Compound 4: the middle estimate sits 1.3-fold (0.11 log units) below what was measured; measured number inside the range.
By their numbers in this assay, from the lowest: compounds 2, 1, 4 and 3 (each within the scatter of the next, the first and the last beyond it).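

In this assay the change to morpholin-4-yl gives a 1.1-fold higher number from compound 1 to compound 4 (0.05 log units; within the scatter) and a 1.2-fold lower number from compound 3 to compound 4 (0.09 log units; within the scatter), so a non-aromatic ring holding a nitrogen and an oxygen cannot be told apart at this position from either 3,5-difluorophenyl or 1-propanoylpiperidin-4-yl. With a 2.3-fold higher number from compound 2 to compound 4 (0.35 log units; beyond the scatter) as a second modest step beyond the scatter, compound 2 now lies apart from both compound 3 and compound 4, although compound 1 goes against a clean split into two groups, as it stays within the scatter of all three other compounds. Nothing shown explains why the 1-isopropyl-1H-pyrazol-4-yl group differs from these two groups in this way.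

The compounds leave open whether an open-chain amine such as dimethylamino or a ring with a second nitrogen such as piperazin-1-yl on the sulfonyl sulfur would stay with compound 1, compound 3 and compound 4 or come closer to compound 2. They also leave open whether a pyrazol-4-yl carrying methyl or a longer chain in place of isopropyl would keep the number of compound 2.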